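Cyclopropyl in place of isopropyl on an aromatic nitrogen

A few compounds are considered here, and "the series" means these few. Any claim that something is new, unique, unknown or untested is made for them only; others in the source may bear on it.

Two compounds of the series have readings so far in an ADME assay on C8166 cells (Homo sapiens) for cytotoxicity, read by MTT assay; on this read-out higher numbers stand for lower toxicity in this test and lower numbers for higher toxicity in this test. Compound 1 `CCCCn1cc(C(=O)O)c(=O)c2c(O)c(Cc3cccc(Cl)c3F)ccc21`, with butyl on an aromatic nitrogen, gives 20000 nM. Compound 2 `CC(C)n1cc(C(=O)O)c(=O)c2c(O)c(Cc3cccc(Cl)c3F)ccc21`, with isopropyl at that nitrogen, gives 26500 nM. Among the compounds with values here, these two readings lie within the scatter of each other, so compound 2 is not separated from the only other number available.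

Compound 3 `O=C(O)c1cn(C2CC2)c2ccc(Cc3cccc(Cl)c3F)c(O)c2c1=O` keeps the shared core and carries cyclopropyl in place of isopropyl on an aromatic nitrogen. Within the data shown here, the one measured step that bears on this change is a 1.3-fold higher number from compound 1 to compound 2 (0.12 log units; within the scatter), also a swap of the group on that nitrogen. Among the measured compounds shown here, no measured compound carries a ring at this place, so the evidence is thin. Compound 2 serves as the anchor at 26500 nM, and no step beyond the scatter is expected in this assay, in either direction. The expected change is a 1.1-fold lower number from compound 2 to compound 3 (0.04 log units; within the scatter). For compound 3 the estimated value is 24000 nM, with an expected range of 11000 nM to 50000 nM.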

Compound 3, half-maximal cytotoxic concentration: 39100 nM
The estimate for compound 3 lay 1.6-fold (0.21 log units) below the measured number; the range from low to high includes it.
By their numbers in this assay, from the lowest: compounds 1, 2 and 3 (each within the scatter of the next).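

In this assay, within the data shown here, cyclopropyl brings a ring to this aromatic nitrogen for the first time, and the swap for isopropyl, with the same count of heavy atoms, gives a 1.5-fold higher number from compound 2 to compound 3 (0.17 log units; within the scatter). Set against the butyl compound, the same ring gives a 2.0-fold higher number from compound 1 to compound 3 (0.29 log units; within the scatter), so all three pairs among butyl, isopropyl and cyclopropyl now stand within the scatter of each other. On these three compounds, a straight chain, a branched chain and a three-membered ring at this nitrogen give readings that cannot be separated in this test, and no supporting data bear on these readings.

Still open, on these data alone, is whether a larger or differently built group at this nitrogen, such as cyclohexyl, phenyl or a hydroxyethyl or aminoethyl chain, would give a step beyond the scatter. All three compounds share the rest of the core, so they also say nothing about other places, for instance an amide in place of the carboxy group.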